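This account rests on a few compounds, and the source may have more. Where it says the series, first, only, none or still open, it means among the compounds named here.

Compounds measured so far:
compound 1 `CNC(=O)[C@H]1CC[C@@H](Nc2cc(NCc3cnccc3C(F)(F)F)ncc2C#N)CC1` — in an assay on isolated protein for inhibition of protein kinase C theta type (Homo sapiens), read by TR-FRET, with a stated time of 2 h (a lower number here means a stronger inhibitor, a higher number a weaker inhibitor), compound 1 gives 27 nM
compound 2 `CC1(C)[C@@H](C(N)=O)C[C@H]1Nc1cc(NCc2cnccc2C(F)(F)F)ncc1C#N` — in this assay compound 2 gives 1.4 nM

Among the two numbers shown, compound 2 stands lowest: the single measured step, a 19-fold lower number from compound 1 to compound 2 (1.29 log units; beyond the scatter), separates it from compound 1, which is its only neighbour, and that step is the only one recorded.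

Compound 3 `CC1(C)[C@H](Nc2cc(NCc3cnccc3C(F)(F)F)ncc2C#N)C[C@H]1C(N)=O` is next. It differs from compound 2 in this way: the two compounds have the same atoms and bonds and differ only in configuration as drawn: 1 of 2 stereo elements differ; a stereocentre at a saturated ring carbon is drawn S in compound 2 and R in compound 3. For the measured compounds named here, no measured step involves a change of configuration alone; the one step on record, a 19-fold lower number from compound 1 to compound 2 (1.29 log units; beyond the scatter), exchanges one saturated ring for another and so does not speak to an epimer of compound 2. The data therefore give no direction for this change, and a stereochemical inversion on a ring that carries the amide may move the number either way or leave it within the scatter. Compound 3 is expected to show a 4.3-fold higher number from compound 2 to compound 3 (0.63 log units; beyond the scatter) relative to compound 2, with the estimate for compound 3 placed at 6 nM in this assay, in a range from 1.5 nM to 30 nM.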

Compound 3, half-maximal inhibitory concentration: 140 nM
Beside the measured number, compound 3's estimate is 23-fold (1.37 log units) below it; the whole stated range lies below it.
By their numbers in this assay, from the lowest: compound 2; then compound 1; then compound 3.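

In this assay, for the compounds shown here, the configuration at one saturated ring carbon of the 3-carbamoyl-2,2-dimethylcyclobutyl group proves decisive, with a 100-fold higher number from compound 2 to compound 3 (2.00 log units; beyond the scatter), and no earlier pair had tested configuration alone. This large step can be assigned to that single stereocentre because nothing else separates the two structures: the fact that compounds 2 and 3 differ only in the configuration as drawn. It also qualifies the earlier gain from replacing the 4-(methylcarbamoyl)cyclohexyl group, since a 19-fold lower number from compound 1 to compound 2 (1.29 log units; beyond the scatter) reverses direction in the epimer, with a 5.2-fold higher number from compound 1 to compound 3 (0.71 log units; beyond the scatter), so the ring exchange does not lower the number in itself and its outcome depends on the configuration drawn.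

The compounds shown leave open what inverting the second stereocentre, which compound 2 and compound 3 share, would do to the number, alone or together with the first. They also leave open whether a methylcarbamoyl group, a carboxylic acid or an amine in place of the carbamoyl group on the cyclobutyl ring would retain the low number of compound 2, and whether the same sensitivity to configuration would then persist.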